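From Branched Alkyl to Cyclohexylethyl on the Nitrogen

The source may report more compounds than this note shows. Statements on the series, on what has been measured and on what is new or still open speak of the compounds shown alone.

Compound 1, `CC(/N=c1\c(O)c(O)\c1=N/c1cncc(Br)c1)C(C)(C)C`: 11700 nM
Compound 2, `CC(/N=c1\c(O)c(O)\c1=N/c1ccc(OC(F)(F)F)cc1)C(C)(C)C`: a limit, > 30000 nM
Compound 3, `CC(C)C(C)/N=c1\c(O)c(O)\c1=N/c1ccc(C#N)cc1`: 1900 nM

In a functional assay for inhibition, with Rattus norvegicus as the target (a lower number here means a stronger inhibitor, a higher number a weaker inhibitor), compound 3 has the lowest of the two numbers that were determined. Compound 1 sits at a higher number, beyond the scatter. Compound 2 gives only a limit, > 30000 nM; this is the limit of > 30000 nM in this assay, at which 1 of the 3 values shown sits.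

Compound 4, `C[C@@H](/N=c1\c(O)c(O)\c1=N/c1ccc(C#N)cc1)C1CCCCC1`, differs from compound 3 in one place: 1-cyclohexylethyl in place of 1,2-dimethylpropyl on a double-bonded nitrogen. Among the compounds with values here, no measured pair differs in just this place, so the size of such a step is unknown. The expected step is small, at most a modest move to a lower number, and may stay within the scatter: a 1.6-fold lower number from compound 3 to compound 4 (0.20 log units; within the scatter). Compound 4 is therefore estimated at 1200 nM, in the range 400 nM to 4000 nM.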

Compound 4, half-maximal inhibitory concentration: 2600 nM
Compound 4: middle estimate off by 2.2-fold (0.34 log units), on the low side; measured number inside the range.
By their numbers in this assay, from the lowest: compounds 3 and 4 (each within the scatter of the next); then compound 1. At a limit, above all of these: compound 2.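

In this assay, the change from 1,2-dimethylpropyl to the larger 1-cyclohexylethyl on the double-bonded nitrogen gives a 1.4-fold higher number from compound 3 to compound 4 (0.14 log units; within the scatter), so the number does not really move. Within the data shown here, this is the first pair differing in one place only, and it shows that this position tolerates a six-membered carbon ring. Nothing measured here explains that tolerance. On these data alone, whether an amine on the cyclohexyl ring, or a phenyl ring in its place, would be tolerated as well remains open. So does the effect of the opposite stereocentre in 1-cyclohexylethyl.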